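The source may hold more compounds than are shown below. What is called first, only, known or untested is meant among the compounds shown, and "the series" means these compounds.

Of the compounds shown here, three have so far been measured in an assay on HEK293 cells for displacement of a labelled ligand from growth hormone secretagogue receptor type 1 (Homo sapiens), with a stated time of 60 min; a higher number here means a weaker inhibitor, a lower number a stronger inhibitor. Compound 1 `COc1ccc(-n2cc3nc(-c4cccnc4C)n(C[C@H]4CCCN(C[C@H]5CCCO5)C4)c(=O)c3n2)cc1` gives 52 nM in this assay. Compound 2 `Cc1ccccc1-c1nc2cn(-c3cccc(C#N)c3)nc2c(=O)n1CC1CCCN(C(C)C)C1` gives 32 nM. Compound 3 `Cc1ncccc1-c1nc2cn(-c3cccc(OC(F)F)c3)nc2c(=O)n1C[C@H]1CCCN(C[C@H]2CCCO2)C1` gives 27 nM. Compound 2 stands second highest of these three numbers; its nearest neighbour is compound 3 and its furthest is compound 1, yet both gaps lie within the scatter, so on this evidence the three compounds cannot be told apart.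

Compound 4 `COc1cccc(-n2cc3nc(-c4ccccc4C)n(CC4CCCN(C(C)C)C4)c(=O)c3n2)c1` has not yet been measured. It differs from compound 2 in a single place: methoxy in place of cyano on an aromatic carbon. Seen one bond further out, a 3-cyanophenyl becomes a 3-methoxyphenyl.

Within the data shown here, only one measured step bears on this change: a 1.9-fold lower number from compound 1 to compound 3 (0.28 log units; within the scatter). That step also exchanged the group on the phenyl ring carried on an aromatic nitrogen, and it moved the number by no more than the scatter. Among the measured compounds shown here, no measured pair exchanges cyano for methoxy directly, so nothing speaks for a step beyond the scatter in either direction. The expected result is therefore a step of a 1.1-fold higher number from compound 2 to compound 4 (0.04 log units; within the scatter), with no direction claimed. Compound 4 is accordingly estimated at 35 nM, within a range from 15 nM to 80 nM.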

Compound 4, half-maximal inhibitory concentration: 1.8 nM
For compound 4 the middle estimate is 19-fold (1.29 log units) above the measured one; measured number below the stated range.
By their numbers in this assay, from the lowest: compound 4; then compounds 3, 2 and 1 (each within the scatter of the next).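

In this assay, the step from cyano to methoxy is large: an 18-fold lower number from compound 2 to compound 4 (1.25 log units; beyond the scatter). The two groups match in what can be counted, with two heavy atoms each, one hydrogen-bond acceptor each, no hydrogen-bond donor and no net charge, so these counts do not separate them, yet the number still moves well beyond the scatter. The earlier step on this phenyl ring, a 1.9-fold lower number from compound 1 to compound 3 (0.28 log units; within the scatter), stayed within the scatter, whereas this pair shows that a single exchange on this aromatic carbon, meta to a large group, can change the number substantially, although nothing measured here explains why.

Going by these compounds, this finding rests on one pair sharing one set of other groups, so it remains open whether the same exchange would have a similar effect alongside the different groups carried by compound 1 and compound 3. Also open, on these data alone, is how an ethoxy group, a hydroxy group or a chlorine atom on the same aromatic carbon would compare, and so whether this result is particular to methoxy or extends to other groups.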